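The source may report more compounds than this note shows. Statements on the series, on what has been measured and on what is new or still open speak of the compounds shown alone.

Measured compounds:
- compound 1 `O=C1C=C(N2CCC2)C(=O)c2c1nc1n2[C@H]2OC[C@@H](O)[C@H]2OC1` gives > 16000 nM in a functional assay on MGC-803 cells (Homo sapiens) for inhibition, read by sulforhodamine B assay; on this read-out lower numbers stand for stronger inhibition and higher numbers for weaker inhibition; this is a limit of the assay, not a number.
- compound 2 `COc1ccc(NC2=CC(=O)c3c(nc4n3[C@H]3OC[C@@H](O)[C@H]3OC4)C2=O)cc1` gives 2150 nM in this assay.
- compound 3 `O=C1C(N2CCC2)=CC(=O)c2c1nc1n2[C@H]2OC[C@@H](O)[C@H]2OC1` gives > 16000 nM in this assay; this again is a limit, not a number.

Compound 1 therefore stands at the edge of what this assay can report, and only a limit is known for it; the same holds for compound 3, so compound 2 is the only one of the three with a measured number (the limit of > 16000 nM in this assay, at which 2 of the 3 values shown sit).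

Compound 4 `Cc1ccc(NC2=CC(=O)c3nc4n(c3C2=O)[C@H]2OC[C@@H](O)[C@H]2OC4)cc1` differs from compound 1 in one place: (4-methylphenyl)amino in place of azetidin-1-yl on a double-bonded ring carbon. Within the data shown here, the one measured step that resembles this change is an at least 7.4-fold higher number from compound 2 to compound 3 (0.87 log units; beyond the scatter), which runs in the opposite direction: replacing an arylamino group by azetidin-1-yl on a double-bonded ring carbon at the other position of the shared core lost a good deal of inhibition. Reading that step backwards, putting an arylamino group in place of azetidin-1-yl on compound 1 is expected to bring compound 4 into the measurable range, with a step of about an at least 6.4-fold lower number from compound 1 to compound 4 (0.80 log units; beyond the scatter) expected.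

Compound 4 is therefore expected to give roughly 2500 nM in this assay, most plausibly between 800 nM and 8000 nM.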

Compound 4, half-maximal inhibitory concentration: 1420 nM
Compound 4: the middle estimate sits 1.8-fold (0.25 log units) above what was measured; low and high end bracket the measured number.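

In this assay, the double-bonded ring carbon that carries azetidin-1-yl in compound 1 proves open to improvement: with (4-methylphenyl)amino on it, the result is an at least 11-fold lower number from compound 1 to compound 4 (1.05 log units; beyond the scatter), a large change well beyond the usual scatter. The earlier step, an at least 7.4-fold higher number from compound 2 to compound 3 (0.87 log units; beyond the scatter), therefore no longer stands alone, since these two pairs now both tie azetidin-1-yl to the weaker result and an arylamino group to the stronger one, although two pairs are all the evidence there is for this pattern. The size of the new step is only a lower bound because one end of it is not a true number: the limit of > 16000 nM in this assay, at which 2 of the 4 values shown sit.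

The entering group brings an aromatic ring and a hydrogen-bond donor together, so these compounds cannot separate what each contributes at this ring carbon. Also left open is how a benzylamino group, an open-chain amine such as diethylamino, or a (4-chlorophenyl)amino group would behave on the same carbon, and whether any of them would give a lower number than compound 4.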